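The source may hold more compounds than are shown below. What is called first, only, known or untested is meant among the compounds shown, and "the series" means these compounds.

Measured so far in an assay on HEK293 cells for displacement of a labelled ligand from growth hormone secretagogue receptor type 1 (Homo sapiens), with a stated time of 60 min; on this read-out higher numbers stand for weaker inhibition and lower numbers for stronger inhibition:
compound 1 `CN1CCN(CCCS(=O)(=O)c2ccc3nc(NC(=O)NC(=O)c4cc(-n5cccc5)ccc4Cl)sc3c2)CC1`, giving 0.15 nM
compound 2 `CS(=O)(=O)c1ccc2nc(NC(=O)NC(=O)c3ccccc3Cl)sc2c1`, giving 120 nM
compound 3 `CCN(CC)CCCS(=O)(=O)c1ccc2nc(NC(=O)NC(=O)c3ccccc3Cl)sc2c1`, giving 13 nM

Within the data shown here, compound 1 gives the lowest number of the three, so it is the strongest inhibitor here; the one measured step, a 9.2-fold lower number from compound 2 to compound 3 (0.97 log units; beyond the scatter), concerns the chain on the sulfonyl sulfur and not the part changed now. Compound 4 `CN1CCN(CCCS(=O)(=O)c2ccc3nc(NC(=O)NC(=O)c4cc(N5CCCC5)ccc4Cl)sc3c2)CC1` differs from compound 1 in one place: pyrrolidin-1-yl in place of 1H-pyrrol-1-yl on an aromatic carbon. Among the measured compounds shown here, no measured pair shows what this exchange does, so there is no ground to expect a step beyond the scatter in this assay in either direction, only uncertainty wider than for a change already seen. Compound 4 is therefore expected to give 0.3 nM, within 0.06 nM to 1.5 nM, an expected step of a 2.0-fold higher number from compound 1 to compound 4 (0.30 log units; within the scatter).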

Compound 4, half-maximal inhibitory concentration: 0.29 nM
Compound 4: middle estimate off by 1.0-fold (0.01 log units), on the high side; the range from low to high includes it.
By their numbers in this assay, from the lowest: compounds 1 and 4 (each within the scatter of the next); then compound 3; then compound 2.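

In this assay, the step on this aromatic carbon, para to a chloro group, is a 1.9-fold higher number from compound 1 to compound 4 (0.29 log units; within the scatter), so the assay does not separate the two compounds. For this pair, replacing the aromatic five-membered ring with the non-aromatic one, with the same 5 heavy atoms, leaves the read-out within the usual scatter. Nothing measured here says what lies behind this result. From the compounds shown here alone, whether a six-membered ring such as morpholin-4-yl or an open-chain amine such as dimethylamino would fit this position equally well remains open. So does whether the pair would read the same with a different chain on the sulfonyl sulfur.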